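This account rests on a few compounds, and the source may have more. Where it says the series, first, only, none or still open, it means among the compounds named here.

Measured so far, in an assay on CHO cells for displacement of a labelled ligand from adenosine receptor A3 (Homo sapiens), read by scintillation counting, with a stated time of 120 min, tested at 10 uM; a lower number here means less inhibition, a higher number more inhibition at the concentration tested (going by the name of the read-out):

compound 1 `CC(C)N1CCN(Cc2csc(N)c2C(=O)c2ccc(Cl)cc2)CC1`: 0%
compound 2 `Nc1scc(CN2CCN(c3ccccc3C(F)(F)F)CC2)c1C(=O)c1ccc(Cl)cc1`: 0%

Compound 2 stands level with compound 1 on these numbers; the change at the ring nitrogen between them gave no change at the digits printed from compound 1 to compound 2 (within the scatter), which is no movement at all. Neither compound shows measurable inhibition at the concentration tested.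

Compound 3 `Nc1scc(CN2CCN(c3ccc(OC(F)(F)F)cc3)CC2)c1C(=O)c1ccc(Cl)cc1` differs from compound 2 in one place: 4-(trifluoromethoxy)phenyl in place of 2-(trifluoromethyl)phenyl on an amine nitrogen in a ring. Among the compounds with values here, the only measured step that bears on this position is no change at the digits printed from compound 1 to compound 2 (within the scatter), where a much larger change in the group carried by the same ring nitrogen left the read-out where it was. With both known compounds reading no inhibition, nothing in the data suggests that a further swap of this aryl group would move the number, so the expected step is none beyond the scatter, no change at the digits printed from compound 2 to compound 3 (within the scatter). Compound 3 is therefore estimated at 0%, with a range from 0% to 12%.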

Compound 3, a percentage reported as inhibition, at one concentration (the size of the read-out at that concentration, not a potency): 1%
Beside the measured number, compound 3's estimate is 1 percentage points below it; low and high end bracket the measured number.
By their numbers in this assay, from the lowest: compounds 1, 2 and 3 (each within the scatter of the next).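

In this assay, putting 4-(trifluoromethoxy)phenyl in place of 2-(trifluoromethyl)phenyl on the ring nitrogen gives a number 1 percentage points higher from compound 2 to compound 3 (within the scatter), so this swap, which also brings in an oxygen and places the substituent elsewhere on the aromatic ring, leaves the read-out within its usual scatter. Set against the isopropyl group, the same aryl group gives a number 1 percentage points higher from compound 1 to compound 3 (within the scatter), which makes this the second aryl group on this nitrogen to read alike with isopropyl. Nothing measured here offers a reason for this flat result.

All three compounds sit close to no inhibition, so these numbers do not show whether this position can influence the read-out at all. From the compounds shown here alone, it remains open whether a carboxylic acid, an amine or a longer chain on this nitrogen, or a change elsewhere in the shared core, would give measurable inhibition.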